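Swapping isopropyl for cyclopropyl at a cytotoxicity limit

This account rests on a few compounds, and the source may have more. Where it says the series, first, only, none or still open, it means among the compounds named here.

Measured in an ADME assay on Akata cells (Homo sapiens) for cytotoxicity, with a stated time of 7 days; a higher number here means that more compound is tolerated, a lower number that less compound is tolerated:
- Compound 1 `C=CCOc1nc(N)nc2c1ncn2/C=C1/CC1(CO)CO`: > 20000 nM, a limit
- Compound 2 `CC(C)Nc1nc(N)nc2c1ncn2/C=C1/CC1(CO)CO`: > 24000 nM, a limit

Neither compound has an exact number, so neither can be ranked against the other. Compound 2 stands only at a limit, > 24000 nM. The next compound, compound 3 `Nc1nc(NC2CC2)c2ncn(/C=C3/CC3(CO)CO)c2n1`, keeps the shared core and alters one group: cyclopropyl in place of isopropyl on a nitrogen on an aromatic ring. In short, isopropylamino gives way to cyclopropylamino.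

For the measured compounds named here, only one measured step touches this group, and it is a step that the two limits leave unreadable from compound 1 to compound 2. That step brought the isopropylamino group in, but it offers no size to carry forward. The expectation for compound 3 therefore rests on compound 2 at > 24000 nM, which is a limit. No step beyond the usual scatter is expected in this assay, in either direction, and another limit would be no surprise. The expected step is a step that the limit leaves unreadable from compound 2 to compound 3. For compound 3 the estimated value is 30000 nM, with an expected range from 10000 nM to 100000 nM.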

Compound 3, half-maximal cytotoxic concentration: > 20000 nM
Compound 3: no number, only a limit (the forecaster's own chance of this, stated with the estimate: 60%); the middle value lies beyond the limit too.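

For the compounds shown here, compound 3 stands only at a limit, > 20000 nM, so no step from compound 1 or compound 2 to compound 3 can be read. The compounds shown leave open whether allyloxy, isopropylamino and cyclopropylamino differ at all in cytotoxicity, and at what concentration any of the three would harm these cells.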